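The source may hold more compounds than are shown below. What is called first, only, known or untested is meant among the compounds shown, and "the series" means these compounds.

Measured so far:
compound 1, `CCCCCc1ccc(NS(=O)(=O)c2ccc(N3CCNC3=O)cc2)cc1`: 870 nM
compound 2, `COc1ccc(NS(=O)(=O)c2ccc(N3CCNC3=O)cc2)cc1`: 580 nM
compound 3, `CCCCOc1ccc(NS(=O)(=O)c2ccc(N3CCNC3=O)cc2)cc1`: 580 nM

All three values come from a functional assay on M21 cells (Homo sapiens) for antiproliferative activity, read by sulforhodamine B assay, with a stated time of 48 h; a higher number here means a weaker inhibitor, a lower number a stronger inhibitor. Compound 2 stands level with compound 3 at the digits given, and together they hold the lowest of the three numbers; the gap to compound 1, a 1.5-fold lower number from compound 1 to compound 2 (0.18 log units; within the scatter), is within the scatter, as are a 1.5-fold lower number from compound 1 to compound 3 (0.18 log units; within the scatter) and no change at the digits printed from compound 2 to compound 3 (within the scatter). On these numbers the three measured compounds cannot be told apart.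

Compound 4, `COc1ccccc1NS(=O)(=O)c1ccc(N2CCNC2=O)cc1`, has not yet been measured. It differs from compound 2 in one place: 2-methoxyphenyl in place of 4-methoxyphenyl on a sulfonamide nitrogen. The two compounds hold the same atoms, joined differently.

For the measured compounds named here, no measured step bears directly on this change. Each of the three steps swaps one group for another at the same place on the ring, and each stayed within the scatter, so there is no guide to what rearranging the same atoms does. The only hint is that the three variations at this ring left this assay little moved, so a step beyond the scatter cannot be ruled in or out. I expect compound 4 to give about 1500 nM, with a range from 400 nM to 6000 nM, which is an estimated 2.6-fold higher number from compound 2 to compound 4 (0.41 log units; beyond the scatter).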

Compound 4, half-maximal inhibitory concentration: 300 nM
The estimate for compound 4 lay 5.0-fold (0.70 log units) above the measured number; measured number below the stated range.
By their numbers in this assay, from the lowest: compounds 4, 2, 3 and 1 (each within the scatter of the next, the first and the last beyond it).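

The earlier steps shown here each put a different group on the ring, whereas this one keeps the same atoms and only rearranges them. In this assay, 2-methoxyphenyl in place of 4-methoxyphenyl on the sulfonamide nitrogen gives a small step (a 1.9-fold lower number from compound 2 to compound 4 (0.29 log units; within the scatter)), so this rearrangement, like the earlier swaps, cannot be separated from ordinary repeat-to-repeat variation. For this pair, the assay therefore accepts either arrangement without a clear difference, although two compounds say nothing about other groups, and no supporting measurement is available to explain the result.

The compounds shown leave open whether any change on this ring can move this assay clearly beyond the scatter, for instance an amine, a carboxylic acid or a longer chain in the place held by methoxy. They also leave open whether the rearrangement would give a similarly small step with a butoxy group, which would show whether the result for this pair extends beyond methoxy.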